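This account rests on a few compounds, and the source may have more. Where it says the series, first, only, none or still open, it means among the compounds named here.

- Compound 1 `Cc1cc(=O)c2c(O)cc(OC/C=C/c3ccccc3)c([C@H]3CCN(C)C[C@H]3O)c2o1` gives 18%
- Compound 2 `Cc1cc(=O)c2c(O)c(CN3CCCC3CO)c(O)c([C@H]3CCN(C)C[C@H]3O)c2o1` gives 15%
- Compound 3 `Cc1cc(=O)c2c(O)c(CN3CCC(Cc4ccccc4)CC3)c(O)c([C@H]3CCN(C)C[C@H]3O)c2o1` gives 16%

All three were read in a functional assay on PC-3 cells (Homo sapiens) for inhibition, read by MTT assay, with a stated time of 48 h, tested at 10 uM (a lower number here means less inhibition of growth, a higher number more inhibition of growth at the concentration tested), and lie within the scatter of one another, so compound 2 stands level with the other two and no order can be drawn. Compound 4 `Cc1cc(=O)c2c(O)c(CN(C(C)C)C(C)C)c(O)c([C@H]3CCN(C)C[C@H]3O)c2o1` has yet to be read, and its change from compound 2 is diisopropylamino in place of 2-(hydroxymethyl)pyrrolidin-1-yl on a saturated chain carbon bound to an aromatic carbon on the shared core. For the measured compounds named here, no measured pair shows this change alone. Compound 3 also carries another group in that place, yet compound 2 gives 15% and compound 3 gives 16% as values within the scatter of each other. No step beyond the scatter is therefore expected, in either direction. The expected size is a number 2 percentage points higher from compound 2 to compound 4 (within the scatter) in this estimate. For compound 4 the estimated value is 17% with an expected range from 7% to 30% in this estimate.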

Compound 4, percent growth inhibition at one concentration: 0%
Compound 4: the middle estimate sits 17 percentage points above what was measured; measured number outside the range, below it.
By their numbers in this assay, from the lowest: compound 4; then compounds 2, 3 and 1 (each within the scatter of the next).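

In this assay, the group on a saturated chain carbon bound to an aromatic carbon does matter: diisopropylamino in place of 2-(hydroxymethyl)pyrrolidin-1-yl gives a number 15 percentage points lower from compound 2 to compound 4 (beyond the scatter) with the count of heavy atoms unchanged. The entering group has no ring and no hydrogen-bond donor, so this place is not open to every amine. Nothing measured here accounts for the step.

The compounds shown leave open whether the ring or the hydroxymethyl group is what counts. A plain pyrrolidin-1-yl or a diethylamino group in that place would begin to separate the two.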